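Series notes: aryl hydrazone acids dosed in the rat

A few compounds are considered here, and "the series" means these few. Any claim that something is new, unique, unknown or untested is made for them only; others in the source may bear on it.

Measured so far:
compound 1, `CC1CC/C(=N\Nc2ccc(Br)cc2)c2ncc(C(=O)O)c(=O)n21` — > 1000 umol/kg
compound 2, `CC1CC/C(=N\Nc2ccc(O)cc2)c2ncc(C(=O)O)c(=O)n21` — > 100 umol/kg

Compound 2 stands at a limit only: in a functional assay on the whole organism for inhibition, with Rattus norvegicus as the target (a higher number here means that more compound is needed for the effect, a lower number that less compound is needed), compound 2 gives > 100 umol/kg, which is a limit of the assay and not a number. Compound 1 likewise gives only a limit, > 1000 umol/kg. Going by the values given here, the one measured step, a step that the two limits leave unreadable from compound 1 to compound 2, is therefore unreadable in size because the limit of > 100 umol/kg in this assay, at which 1 of the 2 values shown sits, and the limit of > 1000 umol/kg in this assay, at which 1 of the 2 values shown sits, are both limits, so neither its direction nor its magnitude can be taken from them.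

Compound 3, `Cc1ccc(N/N=C2\CCC(C)n3c2ncc(C(=O)O)c3=O)cc1`, differs from compound 2 by methyl in place of hydroxy on an aromatic carbon. Among the compounds with values here, no measured step bears on this change: the step from compound 1 to compound 2 cannot be read, and both values on hand sit at limits. There is thus no ground to expect a step beyond the scatter in either direction; the expected step that the limit leaves unreadable from compound 2 to compound 3 is set near nothing, and a limit is the most likely report for compound 3 as well. The estimate for compound 3 in this assay is 300 umol/kg, with a range from 100 umol/kg to 3000 umol/kg.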

Compound 3, dose for 50% inhibition: > 1000 umol/kg
Compound 3 ended at the assay's limit; the forecaster's own chance of this, stated with the estimate: 70%; middle value at least 3.3-fold (0.52 log units) away from the limit.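

In this assay compound 3 gives > 1000 umol/kg, a limit of the assay and not a number. No step can be read between compound 3 and either compound 1 or compound 2; all three values are limits. The compounds shown leave open how bromo, hydroxy and methyl rank in this assay, and what dose any of them needs for the effect.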